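Carbamate chain shortening in a selenocyanate series

The source may report more compounds than this note shows. Statements on the series, on what has been measured and on what is new or still open speak of the compounds shown alone.

Compound 1 `CC(C)COC(=O)Nc1ccc([Se]C#N)cc1` is measured in a functional assay on MCF7 cells (Homo sapiens) for cytotoxicity, read by MTT assay, with a stated time of 72 h (on this read-out lower numbers stand for stronger inhibition of growth and higher numbers for weaker inhibition of growth), and gives 45500 nM. Going by the values given here, the only other measured member, compound 2 `CCCCCCOC(=O)Nc1ccc([Se][Se]c2ccc(NC(=O)OCCCCCC)cc2)cc1`, carries a diselenide bridge and longer chains and gives in this assay 52900 nM; the two numbers lie within the scatter of each other, so compound 1 stands level with compound 2 and neither can be called more active. Among the compounds with values here, no pair of measured compounds differs in a single place, so the series offers no step to lean on.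

Compound 3 `CCOC(=O)Nc1ccc([Se]C#N)cc1` is not yet measured. It differs from compound 1 by methyl in place of isopropyl on a saturated chain carbon bound to an oxygen next to a carbonyl group. Nothing in the measured data speaks to this change. Compound 3 is expected to give a number close to that of compound 1, and the step of a 1.2-fold higher number from compound 1 to compound 3 (0.08 log units; within the scatter) is estimated to stay within the scatter, with weaker inhibition of growth slightly more likely than stronger. For compound 3 the estimate is 55000 nM, ranging from 25000 nM to 120000 nM.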

Compound 3, concentration for total growth inhibition: 36700 nM
Compound 3: middle estimate off by 1.5-fold (0.18 log units), on the high side; measured number inside the range.
By their numbers in this assay, from the lowest: compounds 3, 1 and 2 (each within the scatter of the next).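

In this assay, going by these compounds alone, the step of a 1.2-fold lower number from compound 1 to compound 3 (0.09 log units; within the scatter) is the first single-place comparison. Methyl in place of isopropyl on a saturated chain carbon bound to an oxygen next to a carbonyl group, read one bond further out as isobutoxy to ethoxy, stays within the scatter, so this pair shows no measurable dependence on that change. No measured information on the compounds bears on this result.

From the compounds shown here alone, whether a benzyl group or a chain ending in an amine or a carboxylic acid at this place would give a step beyond the scatter remains open. Compound 2 differs from compound 1 and compound 3 in more than one place, so the contribution of the selenocyanate group relative to the diselenide bridge also remains unresolved.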